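This account rests on a few compounds, and the source may have more. Where it says the series, first, only, none or still open, it means among the compounds named here.

Measured so far in an ADME assay on HEK293 cells (Homo sapiens) for cytotoxicity, read by MTT assay, with a stated time of 48 h; a lower number here means a stronger inhibitor, a higher number a weaker inhibitor:
compound 1 `CN(C)CCCCn1c(N)c(-c2nc3ccccc3o2)c2nc(C#N)c(C#N)nc21` gives 6240 nM;
compound 2 `CCN(CC)CCCCn1c(N)c(-c2nc3ccccc3o2)c2nc(C#N)c(C#N)nc21` gives 3960 nM;
compound 3 `CN(C)CCn1c(N)c(-c2nc3ccccc3n2C)c2nc(C#N)c(C#N)nc21` gives only a limit of this assay, > 50000 nM.

Compound 1 and compound 2 share a core and differ in one place: diethylamino in place of dimethylamino on a saturated chain carbon, four bonds along the chain from an aromatic nitrogen. That step reads a 1.6-fold lower number from compound 1 to compound 2 (0.20 log units; within the scatter), so the two values sit within the usual scatter of each other. The limit for compound 3 is the same one noted at the limit of > 50000 nM in this assay, at which 1 of the 3 values shown sits. How the core of compound 3 differs from the core of compound 1 is not broken down here.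

Compound 4 `CCN(CC)CCn1c(N)c(-c2nc3ccccc3n2C)c2nc(C#N)c(C#N)nc21` is not yet measured. It stands to compound 3 as compound 2 stands to compound 1: diethylamino in place of dimethylamino on a saturated chain carbon, two bonds along the chain from an aromatic nitrogen. It is the same kind of change, but the place is not identical, as the group sits two bonds along the chain from an aromatic nitrogen in compound 4, four bonds in compound 2. Since compound 3 is known only as a limit, the step from compound 3 to compound 4 is expected as a step that the limit leaves unreadable from compound 3 to compound 4, resting on the small step seen from compound 1 to compound 2. Compound 4 is therefore expected to give about 55000 nM in this assay, most likely again reported only as a limit, in the range 20000 nM to 150000 nM.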

Compound 4, half-maximal inhibitory concentration: 25400 nM
The estimate for compound 4 lay 2.2-fold (0.34 log units) above the measured number; measured number inside the range.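

In this assay, putting diethylamino in place of dimethylamino on the shorter chain gives an at least 1.9-fold lower number from compound 3 to compound 4 (0.29 log units; that floor lies within the scatter). Compound 3 is known only as a limit, > 50000 nM, so this step has a floor but no exact size. The earlier step stays within the scatter and this floor does too, so the data neither show the change carrying over with the same size nor show it acting differently on the two cores: the same change on two cores in this assay, a 1.6-fold lower number (0.20 log units; within the scatter) from compound 1 to compound 2 and an at least 1.9-fold lower number (0.29 log units; that floor lies within the scatter) from compound 3 to compound 4; the limit leaves it open whether they differ

The compounds shown leave open how much of the gap between the two series comes from the chain and how much from the rest of the core, since compound 1 and compound 3 differ in more than one place. They also leave open what a different group at the chain end would do, such as a cyclic amine, a primary amine or a carboxylic acid, or how a longer chain would read on the core of compound 3.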